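Removing a Methyl from a Weak Amide Inhibitor

This account rests on a few compounds, and the source may have more. Where it says the series, first, only, none or still open, it means among the compounds named here.

Compound 1 `Cc1cnn(C(=O)NCc2ccc(OCc3ccccc3)cc2)c1`: 1200 nM
Compound 2 `Cc1cnn(C(=O)N(C)CCN(C)C(c2ccc(OCc3ccccc3)cc2)c2ccc(OCc3ccccc3)cc2)c1`: > 1000000 nM

In an assay on membranes from brain for binding affinity to Fatty-acid amide hydrolase 1 (Mus musculus), read by fluorescence, with stated times of 1 h and 30 min (a lower number here means a stronger inhibitor, a higher number a weaker inhibitor), compound 1 gives 1200 nM. Compound 2, whose structure is `Cc1cnn(C(=O)N(C)CCN(C)C(c2ccc(OCc3ccccc3)cc2)c2ccc(OCc3ccccc3)cc2)c1`, gives only a limit in this assay, > 1000000 nM, so it sits at the limit of > 1000000 nM in this assay, at which 1 of the 2 values shown sits. Compound 3 `CN(CCN(C)C(c1ccc(OCc2ccccc2)cc1)c1ccc(OCc2ccccc2)cc1)C(=O)n1cccn1` differs from compound 2 by hydrogen in place of methyl on an aromatic carbon, a hydrogen in place of methyl on an aromatic carbon. Such a small change is expected to give no step beyond the usual scatter in this assay. The estimate for compound 3 is therefore 1000000 nM, within 200000 nM to 3000000 nM, and the step expected is a number no higher from compound 2 to compound 3 (the limit leaves the size open).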

Compound 3, half-maximal inhibitory concentration: > 1000000 nM
Compound 3: only a limit was reported; the forecaster's own chance of this, stated with the estimate: 85%; the middle value lies on the limit itself.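

Compound 2 and compound 3 both reach only a limit, so no step can be read between them: the limit of > 1000000 nM in this assay, at which 2 of the 3 values shown sit.

Whether going from 4-methyl-1H-pyrazol-1-yl to 1H-pyrazol-1-yl changes inhibitor strength at all stays open in the compounds shown.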